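The compounds below may be only part of what the source reports. "The series", "measured", "known", "first", "only" and "open" are said of these compounds alone.

In an ADME assay (liver) for metabolic stability, with Liver microsome (Homo sapiens) as the target, using microsomes (on this read-out higher numbers stand for fast clearance and lower numbers for slow clearance), compound 1 `Fc1cccc(CNc2nnc(-c3c[nH]c4ncccc34)o2)c1` gives 54 mL.min-1.g-1 and compound 2 `Fc1ccc(CNc2nnc(-c3c[nH]c4ncccc34)o2)cc1` gives 47 mL.min-1.g-1. Compound 3 `c1cncc(CNc2nnc(-c3c[nH]c4ncccc34)o2)c1` gives only a limit, < 14 mL.min-1.g-1, the lowest reading of the three. Pyridin-3-yl in place of a fluorophenyl group accounts for an at least 3.8-fold lower number from compound 1 to compound 3 (0.58 log units; beyond the scatter) and an at least 3.3-fold lower number from compound 2 to compound 3 (0.52 log units; beyond the scatter). Compound 4 `c1cnc2[nH]cc(-c3nnc(NCc4ccncc4)o3)c2c1` differs from compound 3 by pyridin-4-yl in place of pyridin-3-yl on a saturated chain carbon bound to a nitrogen on an aromatic ring, with pyridin-4-yl in place of pyridin-3-yl. For the measured compounds named here, the closest precedent is the exchange of 3-fluorophenyl for 4-fluorophenyl, which gave a 1.1-fold lower number from compound 1 to compound 2 (0.06 log units; within the scatter). On that basis, no step beyond the scatter is expected in this assay, and the expected step is a step that the limit leaves unreadable from compound 3 to compound 4. Compound 4 is estimated at 12 mL.min-1.g-1, within an expected range of 6 mL.min-1.g-1 to 26 mL.min-1.g-1.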

Compound 4, intrinsic clearance in microsomes: < 14 mL.min-1.g-1
Compound 4: no number, only a limit (the forecaster's own chance of this, stated with the estimate: 60%); the middle value is on the limit's open side.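

At this position the lower reading is not tied to pyridin-3-yl: in this assay, pyridin-4-yl also gives a lower reading than either fluorophenyl group (an at least 3.3-fold lower number from compound 2 to compound 4 (0.52 log units; beyond the scatter); an at least 3.8-fold lower number from compound 1 to compound 4 (0.58 log units; beyond the scatter)). The step between the two pyridines cannot be read because compound 3 and compound 4 both give only a limit: the limit of < 14 mL.min-1.g-1 in this assay, at which 2 of the 4 values shown sit.

As far as these compounds go, how far below that limit either compound lies stays open. So does whether pyridin-2-yl, or a longer chain carrying the pyridine, would read as low.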